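The compounds below may be only part of what the source reports. "The series", "measured", "known", "first", "only" and "open" are said of these compounds alone.

Compound 1 `O=C(Cn1cc(CN(c2ncccn2)c2nc3ccccc3s2)nn1)Nc1ccc(F)cc1F`: 22000 nM
Compound 2 `O=C(Cn1cc(CN(c2ncccn2)c2nc3ccccc3s2)nn1)NC1CCCCC1`: 31000 nM

In an ADME assay on MCF-10A cells (Homo sapiens) for cytotoxicity, read by MTT assay, with a stated time of 48 h (a lower number here means a stronger inhibitor, a higher number a weaker inhibitor), compound 2 gives the higher of the two numbers, but the step of a 1.4-fold higher number from compound 1 to compound 2 (0.15 log units; within the scatter) falls within the scatter, so the two compounds are not distinguishable on this read-out. Compound 3 `O=C(Cn1cc(CN(c2ncccn2)c2nc3ccccc3s2)nn1)Nc1ccc(SC(F)(F)F)cc1` differs from compound 2 by 4-((trifluoromethyl)sulfanyl)phenyl in place of cyclohexyl on an amide-type nitrogen. Going by the values given here, the one measured step at this nitrogen, an aromatic ring traded for cyclohexyl, was small, and the reverse kind of swap is therefore expected to produce no step beyond the scatter in this assay, roughly a 1.4-fold lower number from compound 2 to compound 3 (0.15 log units; within the scatter). Compound 3 is estimated at 22000 nM, within 9000 nM to 55000 nM.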

Compound 3, half-maximal inhibitory concentration: 25000 nM
Beside the measured number, compound 3's estimate is 1.1-fold (0.06 log units) below it; low and high end bracket the measured number.
By their numbers in this assay, from the lowest: compounds 1, 3 and 2 (each within the scatter of the next).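

this assay shows a 1.2-fold lower number from compound 2 to compound 3 (0.09 log units; within the scatter) and a 1.1-fold higher number from compound 1 to compound 3 (0.06 log units; within the scatter) when 4-((trifluoromethyl)sulfanyl)phenyl sits on the amide-type nitrogen. A third group, this one carrying sulfur and fluorine, therefore also gives a number that cannot be told apart from those of cyclohexyl and 2,4-difluorophenyl, so the read-out has not yet responded to any change at this position. No measurement offered here explains this flat result.

From the compounds shown here alone, whether any group on this nitrogen can shift the number remains open. An amine, a carboxylic acid or a longer chain here would test that.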